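The source may report more compounds than this note shows. Statements on the series, on what has been measured and on what is new or still open speak of the compounds shown alone.

Two compounds have a reading so far. In a physicochemical assay for solubility, in phosphate buffer, measured as thermodynamic solubility, at pH 7.4 (on this read-out lower numbers stand for lower solubility and higher numbers for higher solubility), compound 1 (`CS(=O)(=O)NC(=O)CCc1cn(-c2ccc(Cl)cc2)nc1-c1ccc(Cl)cc1`) gives 100000 nM as a plain number. In this assay compound 2 (`CNC(=O)CCc1cn(-c2ccc(Br)cc2)nc1-c1ccc(Cl)cc1`) gives < 5000 nM and this is a limit of the assay, not a number, so compound 2 stands only at a limit on this scale.

The next structure, compound 3 (`O=C(CCc1cn(-c2ccc(Br)cc2)nc1-c1ccc(Cl)cc1)NS(=O)(=O)C1CC1`), departs from compound 2 in one place: cyclopropylsulfonyl in place of methyl on an amide-type nitrogen. Among the measured compounds shown here, no measured pair of compounds shows this change on its own, so its size can only be judged indirectly. Compound 1 also carries a sulfonyl group on its amide-type nitrogen, and with compound 1 at 100000 nM an upward move is expected for compound 3. The expected change, an at least 12-fold higher number from compound 2 to compound 3 (1.07 log units; beyond the scatter) in this assay terms, is a large one toward higher numbers and beyond the usual scatter. In this assay the estimated value for compound 3 is 60000 nM with a likely range of 15000 nM to 150000 nM and the measurement is still to come.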

Compound 3, solubility: 5000 nM
Compound 3: the middle estimate sits 12-fold (1.08 log units) above what was measured; the measured number lies below the stated range.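

With cyclopropylsulfonyl on the amide-type nitrogen, compound 3 gives 5000 nM in this assay as a plain number, so one end of this change now has a real reading. Swapping methyl for cyclopropylsulfonyl at this place gives a number no lower from compound 2 to compound 3 (the limit leaves the size open) in the same test, which means the change did not lower the reading. Compound 2 gives < 5000 nM and this is a limit of the assay, not a number, so the gain could be tiny or large, and the size of the step stays unknown because of where compound 2 sits: the limit of < 5000 nM in this assay, at which 1 of the 3 values shown sits.

Compound 1 differs from compound 3 in two places, so their two values cannot be pinned on any single change, and the part played by the sulfonyl group's own substituent stays unsettled. Also open, as far as these compounds go, is how the same nitrogen would read in this assay with a longer chain on the sulfonyl group, such as butylsulfonyl, or how the molecule would read with a carboxylic acid in place of the whole substituted amide.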